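The source may report more compounds than this note shows. Statements on the series, on what has been measured and on what is new or still open speak of the compounds shown alone.

Compound 1 `C/C(=N\NC(N)=O)c1ccc2[nH]c(-c3ccccc3)nc2c1` and compound 2 `C/C(=N\NC(N)=O)c1ccc2[nH]c(-c3ccc(Cl)cc3)nc2c1` share one core and differ in that compound 2 carries chloro in place of hydrogen on an aromatic carbon. In an ADME assay on BHK-21 cells (Mesocricetus auratus) for cytotoxicity, read by MTT assay (a lower number here means that less compound is tolerated, a higher number that more compound is tolerated), compound 1 gives only a limit, > 100000 nM. Compound 2 likewise gives only a limit in this assay, > 100000 nM. The step that the two limits leave unreadable from compound 1 to compound 2 is unreadable because the limit of > 100000 nM in this assay, at which 2 of the 3 values shown sit, caps both values. Among the measured compounds shown here, compound 3 `C/C(=N\NC(N)=S)c1ccc2[nH]c(-c3ccccc3)nc2c1` differs from compound 1 by a group of 3 heavy atoms (1 carbon, 1 nitrogen, 1 sulfur; no ring) in place of a group of 3 heavy atoms (1 carbon, 1 nitrogen, 1 oxygen; no ring), on an amine nitrogen; in this assay compound 3 gives 32000 nM, the only number among the three, and the step is an at least 3.1-fold lower number from compound 1 to compound 3 (0.49 log units; beyond the scatter). Compound 4 `C/C(=N\NC(N)=S)c1ccc2[nH]c(-c3ccc(Cl)cc3)nc2c1` has not yet been measured in this assay; it differs from compound 3 by chloro in place of hydrogen on an aromatic carbon, the same change as between compound 1 and compound 2, at the same place. That earlier step is unreadable, so there is no measured hint that the chloro moves the number either way. The expected step is a 1.1-fold lower number from compound 3 to compound 4 (0.03 log units; within the scatter), resting on the number that compound 3 gave, 32000 nM. The estimate for compound 4 in this assay is 30000 nM, with a likely range from 10000 nM to 100000 nM.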

Compound 4, half-maximal cytotoxic concentration: > 100000 nM
Compound 4 ended at the assay's limit; the forecaster's own chance of this, stated with the estimate: 15%; middle value at least 3.3-fold (0.52 log units) from the limit.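

In this assay, phenyl to 4-chlorophenyl on the sulfur-bearing core gives an at least 3.1-fold higher number from compound 3 to compound 4 (0.49 log units; beyond the scatter), so on this core the chloro goes with more compound being tolerated, and the true size of the step may be larger than the printed figure. The same change on the oxygen-bearing core cannot be read, and neither can the step between the two chloro compounds, because the values at both ends of each are capped: the limit of > 100000 nM in this assay, at which 3 of the 4 values shown sit. The change has therefore been read on one core only, so the series does not show that the effect carries from one core to the other, nor does it show that it fails to carry.

From the compounds shown here alone, what stays open is whether another group on the same phenyl ring, such as a methoxy group or an amine, would also move the number away from that of compound 3. Going by these compounds, it is also open whether chloro has any effect on a compound of the oxygen-bearing core whose number falls within the range of the assay.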